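The source may hold more compounds than are shown below. What is called first, only, known or untested is meant among the compounds shown, and "the series" means these compounds.

Measured compounds:
compound 1 `COc1cccc(CNCCCNc2ccnc3cc(Oc4ccccc4)ccc23)c1O`, 6800 nM;
compound 2 `COc1ccc(Oc2ccc3c(NCCCNCc4cccc(OC)c4O)ccnc3c2)cc1`, 5500 nM;
compound 3 `COc1cccc(CNCCCNc2ccnc3cc(CC(C)C)ccc23)c1O`, 2920 nM.

All three were tested in an ADME assay on HepG2 cells (Homo sapiens) for cytotoxicity, read by luminescence, CellTiter-Glo and ATP content, with a stated time of 72 h; a higher number here means that more compound is needed for the effect, a lower number that less compound is needed. Compound 3 gives the lowest of the three numbers: its step from compound 2 is a 1.9-fold lower number from compound 2 to compound 3 (0.27 log units; within the scatter), while its step from compound 1 is a 2.3-fold lower number from compound 1 to compound 3 (0.37 log units; beyond the scatter), so only the gap to compound 1 counts as a real difference.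

Compound 4 `COc1cccc(CNCCCNc2ccnc3cc(-c4cccc5ccccc45)ccc23)c1O` has not yet been measured. Its change from compound 3 is naphthalen-1-yl in place of isobutyl on an aromatic carbon. The two steps that touch this same position are those from compound 1 and from compound 2 to compound 3, where an isobutyl took the place of a group built on a single aromatic ring and the number went down, modestly or within the scatter. Compound 4 goes the other way: a group of two six-membered aromatic rings of carbon only enters where the isobutyl was. On that basis a modest rise of the number is expected, roughly reversing what those two steps showed, though the entering group is not the same as either that left.

Compound 4 is therefore estimated at 4500 nM, with a likely range from 2000 nM to 10000 nM, which is expected to mean a step of a 1.5-fold higher number from compound 3 to compound 4 (0.19 log units; within the scatter).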

Compound 4, half-maximal effective concentration: 2520 nM
For compound 4 the middle estimate is 1.8-fold (0.25 log units) above the measured one; low and high end bracket the measured number.
By their numbers in this assay, from the lowest: compounds 4, 3, 2 and 1 (each within the scatter of the next, the first and the last beyond it).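

In this assay the replacement of isobutyl by naphthalen-1-yl gives a 1.2-fold lower number from compound 3 to compound 4 (0.06 log units; within the scatter) and so cannot be told apart from no change, even though the entering group has 10 heavy atoms against 4 and brings 2 six-membered aromatic rings where the isobutyl had no ring. Naphthalen-1-yl does stand clear of both phenoxy-type groups, with a 2.2-fold lower number from compound 2 to compound 4 (0.34 log units; beyond the scatter) when it replaces 4-methoxyphenoxy and a 2.7-fold lower number from compound 1 to compound 4 (0.43 log units; beyond the scatter) when it replaces phenoxy, whereas isobutyl is separated beyond the scatter only from phenoxy. Among these four compounds, then, this position tolerates both a branched chain and a large fused aromatic group with no sign of a rising number, and nothing shown here explains the gaps to the phenoxy-type groups.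

Still open, as far as these compounds go, is how a group carrying a charge or hydrogen-bond donors would behave at this carbon, such as an amine or a carboxylic acid. A plain hydrogen at the same place would also show whether any of these groups matters at all in this assay for the cells' response.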